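Swapping an Aryl Group on a Urea in Two Cores

This account rests on a few compounds, and the source may have more. Where it says the series, first, only, none or still open, it means among the compounds named here.

Compound 1 `Cc1ccc(NC(=O)Nc2cccc(CNc3ncnc4ccccc34)c2)cc1` and compound 2 `COc1ccccc1NC(=O)Nc1cccc(CNc2ncnc3ccccc23)c1` share one core. In a functional assay on A549 cells (Homo sapiens) for antiproliferative activity, read by MTT assay (a higher number here means a weaker inhibitor, a lower number a stronger inhibitor), compound 1 gives 24900 nM, and compound 2 gives 30800 nM. The change between them, (2-methoxyphenyl in place of 4-methylphenyl on an amide-type nitrogen), made a step of a 1.2-fold higher number from compound 1 to compound 2 (0.09 log units; within the scatter). Compound 3 `COc1cc2ncnc(NCc3cccc(NC(=O)Nc4ccc(C)cc4)c3)c2cc1OC` rests on a different core; the difference between the two cores is not broken down here. In this assay compound 3 gives 12900 nM. Compound 4 `COc1ccccc1NC(=O)Nc1cccc(CNc2ncnc3cc(OC)c(OC)cc23)c1` has not yet been measured; it differs from compound 3 by the same change, (2-methoxyphenyl in place of 4-methylphenyl on an amide-type nitrogen), at the same place. This expectation rests on the step of a 1.2-fold higher number from compound 1 to compound 2 (0.09 log units; within the scatter), which stayed within the scatter. A similar step of a 1.2-fold higher number from compound 3 to compound 4 (0.07 log units; within the scatter) is expected for the new pair. Compound 4 is estimated at 15000 nM, with a likely range from 7000 nM to 32000 nM.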

Compound 4, half-maximal inhibitory concentration: 15200 nM
Compound 4: the middle estimate sits 1.0-fold (0.01 log units) below what was measured; measured number inside the range.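

Putting 2-methoxyphenyl in place of 4-methylphenyl on the amide-type nitrogen gave, in this assay, a 1.2-fold higher number from compound 3 to compound 4 (0.07 log units; within the scatter). This step matches the one seen earlier on the other core: the same change on two cores in this assay, a 1.2-fold higher number (0.09 log units; within the scatter) from compound 1 to compound 2 and a 1.2-fold higher number (0.07 log units; within the scatter) from compound 3 to compound 4, 1.0-fold (0.02 log units) apart, within the scatter of two such steps

So in these two pairs, the change carries over from one core to the other as a step too small to tell apart from repeat scatter; this shows only that the swap makes no readable difference on either core, not that a change with a large effect would transfer as neatly.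

The compounds shown leave open whether a different group on that nitrogen, such as a cyclohexyl group or a phenyl ring carrying a carboxylic acid, would shift the number beyond the scatter. They also leave open whether such a shift would be the same on both cores.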